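This account rests on a few compounds, and the source may have more. Where it says the series, first, only, none or still open, it means among the compounds named here.

Compound 1, `O=C(COCc1ccccc1)N1CCN(c2ccccc2)CC1`; in a functional assay on HEK293 cells for positive allosteric modulation of metabotropic glutamate receptor 5 (Homo sapiens), read by FLIPR and calcium flux (on this read-out lower numbers stand for an effect already at smaller amounts and higher numbers for an effect only at larger amounts of compound), compound 1 gives 7100 nM.
Compound 2, `O=C(COCc1ccccc1)N1CCN(c2ccccc2Cl)CC1`; in this assay compound 2 gives 1100 nM.
Compound 3, `O=C(COCc1ccccc1)N1CCN(c2ccc(Cl)cc2Cl)CC1`; in this assay compound 3 gives 1000 nM.

All three share one core and differ only in the ring attached to the piperazine nitrogen. Compound 3 and compound 2 sit within the scatter of each other, as the step of a 1.1-fold lower number from compound 2 to compound 3 (0.04 log units; within the scatter) shows, and both stand clearly apart from compound 1: a 6.5-fold lower number from compound 1 to compound 2 (0.81 log units; beyond the scatter) and a 7.1-fold lower number from compound 1 to compound 3 (0.85 log units; beyond the scatter).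

Compound 4, `O=C(COCc1cccnc1)N1CCN(c2ccc(Cl)cc2Cl)CC1`, keeps the 2,4-dichlorophenyl of compound 3 and changes the other end of the molecule: pyridin-3-yl in place of phenyl on a saturated chain carbon bound to an oxygen on a saturated carbon. Among the compounds with values here, none of the measured steps touches this end; every one of them concerns the ring on the piperazine nitrogen, so they give no direct guide to this change. With nothing to point in either direction, the expected step of a 1.5-fold higher number from compound 3 to compound 4 (0.18 log units; within the scatter) is one within the scatter, with a wide margin for an unforeseen shift. Compound 4 is therefore estimated at 1500 nM, in the range 500 nM to 5000 nM.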

Compound 4, half-maximal effective concentration: 1090 nM
Compound 4: the middle estimate sits 1.4-fold (0.14 log units) above what was measured; the measured number falls inside the stated range.
By their numbers in this assay, from the lowest: compounds 3, 4 and 2 (each within the scatter of the next); then compound 1.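

Within the data shown here, this is the first change at the far end of the molecule, away from the ring on the piperazine nitrogen. On a saturated chain carbon bound to an oxygen on a saturated carbon, pyridin-3-yl replaces phenyl, bringing a ring nitrogen and one hydrogen-bond acceptor, and this assay shows a 1.1-fold higher number from compound 3 to compound 4 (0.04 log units; within the scatter) with no change that can be told from scatter. No supporting measurement is available to explain why this swap leaves the number where it was.

On these data alone, it remains open whether an amine, a carboxylic acid or a longer chain at this end would also leave the number in place. As far as these compounds go, it is equally open whether pyridin-3-yl would give the same result with the ring of compound 1 or compound 2 on the piperazine nitrogen.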